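The compounds below may be only part of what the source reports. "The series", "measured", "known", "first", "only" and "open" are said of these compounds alone.

Three compounds with the same core and the same 2-(dimethylamino)ethyl group have been measured in a functional assay on MCF7 cells (Homo sapiens) for antiproliferative activity, read by sulforhodamine B assay, with a stated time of 72 h; on this read-out lower numbers stand for stronger inhibition and higher numbers for weaker inhibition. Compound 1 `CCCCS(=O)(=O)Nc1cc(-c2ccc3ncnc(NCCN(C)C)c3c2)cnc1OC` gives 3240 nM, the second highest of the three numbers. Compound 2 `COc1ncc(-c2ccc3ncnc(NCCN(C)C)c3c2)cc1NS(C)(=O)=O` gives 14700 nM, and compound 3 `COc1ncc(-c2ccc3ncnc(NCCN(C)C)c3c2)cc1NS(=O)(=O)c1ccc(F)cc1` gives 1230 nM, which places compound 1 in the middle.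

Compound 4 `CCCCS(=O)(=O)Nc1cc(-c2ccc3ncnc(NCc4ccncc4)c3c2)cnc1OC` keeps the butyl on the sulfonyl sulfur of compound 1 and changes the other end of the molecule: pyridin-4-yl in place of (dimethylamino)methyl on a saturated chain carbon bound to a nitrogen on an aromatic ring. Put simply, 2-(dimethylamino)ethyl gives way to (pyridin-4-yl)methyl.

The three measured steps all lie on the sulfonyl sulfur: a 4.5-fold higher number from compound 1 to compound 2 (0.66 log units; beyond the scatter), a 2.6-fold lower number from compound 1 to compound 3 (0.42 log units; beyond the scatter) and a 12-fold lower number from compound 2 to compound 3 (1.08 log units; beyond the scatter). They range from modest to large, so a single change in this small set can clearly shift the number. Yet none of them touches the group that changes in compound 4, so they offer no direction for this step. The data contain no measured change at this end of the molecule.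

In this assay, the expected outcome is therefore no step beyond the scatter, with wide uncertainty in either direction. The estimated step is a 1.3-fold lower number from compound 1 to compound 4 (0.11 log units; within the scatter). Compound 4 is estimated at 2500 nM, with an expected range from 600 nM to 10000 nM.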

Compound 4, half-maximal inhibitory concentration: 18700 nM
The estimate for compound 4 lay 7.5-fold (0.87 log units) below the measured number, outside the stated range (above it).
By their numbers in this assay, from the lowest: compound 3; then compound 1; then compounds 2 and 4 (each within the scatter of the next).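

In this assay, the change from 2-(dimethylamino)ethyl to (pyridin-4-yl)methyl gives a 5.8-fold higher number from compound 1 to compound 4 (0.76 log units; beyond the scatter), which shows that the number responds to this end of the molecule as well as to the group on the sulfonyl sulfur, and that this replacement weakens inhibition when butyl stays on the sulfur. The two groups have the same counted hydrogen-bond donors and acceptors, so those counts do not separate them, although an open chain with no ring gives way to a six-membered aromatic ring with one hetero atom. Nothing among the available data explains why the number rises.

A single replacement cannot show whether the pyridine ring or the shorter link to the ring-bound nitrogen matters more, and a 2-(pyridin-4-yl)ethyl group, which keeps the original chain length while carrying the ring, would help to separate the two. From the compounds shown here alone, it also remains open whether a longer chain such as 3-(dimethylamino)propyl would shift the number, and whether this end behaves in the same way with 4-fluorophenyl on the sulfonyl sulfur.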